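A Sulfur-Bearing Side Chain Replaces the Amine

The source may report more compounds than this note shows. Statements on the series, on what has been measured and on what is new or still open speak of the compounds shown alone.

Compound 1, `NC(=O)C[C@H](NC(=O)CN(c1nc(Cl)nc2[nH]cnc12)C1CC1)C(=O)O`: 17%
Compound 2, `NCCCC[C@H](NC(=O)CN(c1nc(Cl)nc2[nH]cnc12)C1CC1)C(=O)O`: 16.4%

In a functional assay on the whole organism (Tail, strain ICR) with Mus musculus as the target, in the tail flick test, with a stated time of 120 min, at a dose of 25 umol/kg by the oral route (on this read-out higher numbers stand for a stronger effect at the one dose given and lower numbers for a weaker effect), compound 1 gives 17% and compound 2 gives 16.4%. Going by the values given here, these are the only two numbers so far, and they sit within the usual scatter of each other, so compound 2 cannot be set apart from compound 1 on this read-out. Among the compounds with values here, the single measured step says the same: a number 0.6 percentage points lower from compound 1 to compound 2 (within the scatter).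

Compound 3, `CSCC[C@H](NC(=O)CN(c1nc(Cl)nc2[nH]cnc12)C1CC1)C(=O)O`, has not yet been measured in this assay. It differs from compound 2 in one place: methylsulfanyl in place of 2-aminoethyl on a saturated chain carbon, three bonds along the chain from an amide-type nitrogen and a carbonyl carbon. Within the data shown here, only one measured step bears on this change, the one that also exchanged the side chain on the shared core, and that step stayed within the scatter. With nothing else to go on, the account expects no step beyond the scatter from this exchange either; the expected change is a number 0.6 percentage points higher from compound 2 to compound 3 (within the scatter). Compound 3 is therefore estimated to give 17% in this assay, with a range from 8% to 27%.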

Compound 3, a percentage reported as activity, at one dose (the size of the read-out at that dose, not a potency): 5.67%
Compound 3: middle estimate off by 11.3 percentage points, on the high side; the whole stated range lies above it.
By their numbers in this assay, from the lowest: compound 3; then compounds 2 and 1 (each within the scatter of the next).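

The exchange at this position, on a saturated chain carbon three bonds along the chain from an amide-type nitrogen and a carbonyl carbon, does register in this assay: methylsulfanyl in place of 2-aminoethyl gives a number 10.7 percentage points lower from compound 2 to compound 3 (beyond the scatter) on this read-out. Measured against the carbamoyl side chain, (methylsulfanyl)methyl gives a number 11.3 percentage points lower from compound 1 to compound 3 (beyond the scatter) and so stands apart from both earlier compounds, which could not be told apart from each other, showing that the side chain here is not interchangeable. What changes in the first of these steps is that 2-aminoethyl, with its nitrogen and its hydrogen-bond donor, leaves and methylsulfanyl, with its sulfur and no such donor, enters, but nothing measured here says why the number falls with that exchange.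

From the compounds shown here alone, what remains open is whether the sulfur itself goes with the lower number or only the loss of a nitrogen-bearing end, a question that a plain butyl chain or a hydroxyl-ended chain at this place could separate. The compounds shown also leave open how a carboxylic acid on the side chain would read.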